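The source may hold more compounds than are shown below. What is called first, only, known or untested is meant among the compounds shown, and "the series" means these compounds.

Measured so far in a functional assay on cells (Mus musculus) for cytotoxicity, read by MTT assay, with a stated time of 24 h; a lower number here means that less compound is needed, a higher number that more compound is needed for the effect:
compound 1, `C=C1CC[C@@H]2[C@](C)(CCC[C@]2(C)C(=O)O)[C@H]1CC/C(C)=C/CO`, gives 63.5 ug/mL.
compound 2, `C=C1CC[C@@H]2[C@](C)(CCC[C@]2(C)C(=O)O)[C@H]1CC/C(C)=C/C(=O)O`, gives 95.9 ug/mL.
compound 3, `C=C1CC[C@@H]2[C@](C)(CCC[C@]2(C)C(=O)O)[C@H]1CC/C(C)=C/C(=O)OC`, reaches only the limit > 100 ug/mL.

Compound 3 therefore stands at the limit of this assay, with the limit of > 100 ug/mL in this assay, at which 1 of the 3 values shown sits; it has no number of its own, only a floor. The measured steps are all small: a 1.5-fold higher number from compound 1 to compound 2 (0.18 log units; within the scatter), an at least 1.5-fold higher number from compound 1 to compound 3 (0.19 log units; that floor lies within the scatter) and an at least 1.0-fold higher number from compound 2 to compound 3 (0.01 log units; that floor lies within the scatter). Within the measured set nothing moves beyond the scatter.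

The next compound, compound 4, is `C=C[C@](C)(O)CC[C@H]1C(=C)CC[C@@H]2[C@]1(C)CCC[C@]2(C)C(=O)O`. It differs from compound 3 in one place: 1-hydroxy-1-methylprop-2-en-1-yl in place of 2-(methoxycarbonyl)-1-methylethenyl on a saturated chain carbon, two bonds along the chain from a saturated ring carbon. The change removes the methoxycarbonyl-bearing chain and brings back a hydroxyl group on a shorter chain. Going by the values given here, the steps that bear on it are those in which the hydroxymethyl of compound 1 was exchanged for carboxy or methoxycarbonyl, a 1.5-fold higher number from compound 1 to compound 2 (0.18 log units; within the scatter) and an at least 1.5-fold higher number from compound 1 to compound 3 (0.19 log units; that floor lies within the scatter), both within the scatter. Reversing the sense of that exchange in compound 4 is expected to give at most a modest step in the direction of a lower number, an at least 1.4-fold lower number from compound 3 to compound 4 (0.15 log units; that floor lies within the scatter), though the limit of compound 3 leaves the size uncertain. Compound 4 is estimated at 70 ug/mL, in the range 35 ug/mL to 140 ug/mL.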

Compound 4, concentration for half-maximal effect: > 100 ug/mL
Compound 4: a limit, no number; the forecaster's own chance of this, stated with the estimate: 30%; at least 1.4-fold (0.15 log units) between middle value and limit.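

In this assay, compound 4 has only a limit and no number of its own, and it is the second compound of the series to do so: the limit of > 100 ug/mL in this assay, at which 2 of the 4 values shown sit.

With 1-hydroxy-1-methylprop-2-en-1-yl on the saturated chain carbon, two bonds along the chain from a saturated ring carbon, a hydroxyl group is again present, yet this gives no readable number, and the step between compound 3 and compound 4 cannot be read. The two readable steps give only floors, an at least 1.0-fold higher number from compound 2 to compound 4 (0.01 log units; that floor lies within the scatter) and an at least 1.5-fold higher number from compound 1 to compound 4 (0.19 log units; that floor lies within the scatter), so compound 4 cannot be separated from compound 1 or compound 2 beyond the scatter, and this shorter hydroxyl-bearing group is not shown to differ from 3-hydroxy-1-methylprop-1-en-1-yl.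

Across the four compounds, no change at this place is shown to move the number beyond the scatter, so it remains open whether this place matters at all for this assay. From the compounds shown here alone, it also remains open whether an amine, an amide or a longer chain ending in a hydroxyl group at this place would give a clearly lower number.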